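Compound 4 in the KB growth series

The source may hold more compounds than are shown below. What is called first, only, known or untested is meant among the compounds shown, and "the series" means these compounds.

Growth inhibition in a functional assay on KB cells (Homo sapiens) for inhibition, read by sulforhodamine B assay, with a stated time of 72 h (on this read-out higher numbers stand for weaker inhibition of growth and lower numbers for stronger inhibition of growth), so far, each entry a limit of the assay
- compound 1 `CN1CCN(C(=O)/C=C/c2ccncc2-c2ccc3ccccc3c2)CC1` gives > 10000 nM as a limit
- compound 2 `CNC(=O)/C=C/c1ccncc1-c1ccc2ccccc2c1` gives > 10000 nM as a limit
- compound 3 `NNC(=O)CCc1ccncc1-c1ccc2ccccc2c1` gives > 10000 nM as a limit

Compound 3 stands at > 10000 nM in this assay and this is a limit, not a number. The other measured compounds share that position, as the limit of > 10000 nM in this assay, at which 3 of the 3 values shown sit, shows for the series.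

Compound 4 `CCOC(=O)/C=C/c1ccncc1-c1ccc2ccccc2c1` comes next, with the change 2-(ethoxycarbonyl)ethenyl in place of 2-(aminocarbamoyl)ethyl on an aromatic carbon on the shared core, where 2-(ethoxycarbonyl)ethenyl replaces 2-(aminocarbamoyl)ethyl on an aromatic carbon opposite the ring nitrogen. Going by the values given here, two measured steps bear on this change, a step that the two limits leave unreadable from compound 1 to compound 2 and a step that the two limits leave unreadable from compound 2 to compound 3 and neither has a readable size. Compound 2 also carries an ethenyl chain at this carbon and gives > 10000 nM as a limit. With no readable step to build on, no step beyond the scatter is expected in either direction in this assay and another limit is the likeliest report. The expected step is a number no higher from compound 3 to compound 4 (the limit leaves the size open) and it remains an estimate. The estimate for compound 4 is 10000 nM with an expected range from 3000 nM to 30000 nM in the same read-out.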

Compound 4, concentration for 50% growth inhibition: > 10000 nM
Compound 4 was reported as a limit; the forecaster's own chance of this, stated with the estimate: 80%; the middle value sits exactly at the limit.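

In this assay compound 4 gives > 10000 nM, which is a limit, not a number. No step can be read from compound 1, compound 2 or compound 3 to compound 4, since every entry is a limit: the limit of > 10000 nM in this assay, at which 4 of the 4 values shown sit.

The compounds shown leave open how strongly any of them inhibits growth and whether any change on the shared core alters it.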